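Chloro in place of fluoro: compound 2 to compound 3

The compounds below may be only part of what the source reports. "The series", "measured", "known", "first", "only" and "open" are said of these compounds alone.

Of the compounds shown here, two have numbers so far. In a functional assay on HCT-116 cells (Homo sapiens) for antiproliferative activity, read by MTT assay, with a stated time of 48 h (a higher number here means a weaker inhibitor, a lower number a stronger inhibitor), compound 1 (`CCCCCCCC(CCO)n1cnc2c(Cl)nc(Cl)nc21`) gives 12800 nM and compound 2 (`CCCCCCCCCC(CCO)n1cnc2c(Cl)nc(F)nc21`) gives 32100 nM on the current data. Compound 2 therefore holds the higher of the two numbers, and its gap to compound 1 lies beyond the scatter. The next compound is compound 3 (`CCCCCCCCCC(CCO)n1cnc2c(Cl)nc(Cl)nc21`), which has chloro in place of fluoro on an aromatic carbon between two ring nitrogen atoms. Going by the values given here, no measured pair shows this exchange, so the expectation is loose. Among the compounds with values here, the only guide is that compound 1 sits at 12800 nM and so lower than compound 2. A modest fall in the number in this assay is expected (a 2.1-fold lower number from compound 2 to compound 3 (0.33 log units; beyond the scatter)) and it may not clear the scatter. For compound 3 the estimated value is 15000 nM with an expected range from 7000 nM to 32000 nM in this assay.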

Compound 3, half-maximal inhibitory concentration: 32600 nM
Compound 3: the middle estimate sits 2.2-fold (0.34 log units) below what was measured; the measured number lies above the stated range.
By their numbers in this assay, from the lowest: compound 1; then compounds 2 and 3 (each within the scatter of the next).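

In this assay, the aromatic carbon between two ring nitrogen atoms shows no readable difference between fluoro and chloro, a 1.0-fold higher number from compound 2 to compound 3 (0.01 log units; within the scatter), so this exchange alone leaves the number in place. The step beyond the scatter lies on the chain instead: ethyl in place of hydrogen on a saturated chain carbon, eight bonds along the chain from an aromatic nitrogen, gives a 2.5-fold higher number from compound 1 to compound 3 (0.41 log units; beyond the scatter). No available data bear on why either step has the size it does.

As far as these compounds go, the chain step rests on a single pair with chloro on the aromatic carbon, so whether it holds with fluoro there, or extends to a longer chain, stays open. From the compounds shown here alone, whether an amine at the same aromatic carbon would depart from the two halogens also remains open.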